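Methyl replaces methoxy on the amide side chain of compound 1

The compounds below may be only part of what the source reports. "The series", "measured", "known", "first", "only" and "open" are said of these compounds alone.

Compound 1 `CC[C@H]1OC(=O)[C@H](C)[C@@H](O[C@H]2C[C@@](C)(OC)[C@@H](OCCCNC(=O)COC)[C@H](C)O2)[C@H](C)[C@@H](O[C@@H]2O[C@H](C)C[C@H](N(C)C)[C@H]2O)[C@](C)(O)C[C@@H](C)CN(C)[C@H](C)[C@@H](O)[C@]1(C)O`: 2.16
Compound 3 `CC[C@H]1OC(=O)[C@H](C)[C@@H](O[C@H]2C[C@@](C)(OC)[C@@H](O)[C@H](C)O2)[C@H](C)[C@@H](O[C@@H]2O[C@H](C)C[C@H](N(C)C)[C@H]2O)[C@](C)(O)C[C@@H](C)CN(CCCNC(C)=O)[C@H](C)[C@@H](O)[C@]1(C)O`: 2.06
Compound 2 `CC[C@H]1OC(=O)[C@H](C)[C@@H](O)[C@H](C)[C@@H](O)[C@](C)(O)C[C@@H](C)CN(C)[C@H](C)[C@@H](O)[C@]1(C)O`: 1.29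

In a physicochemical assay for lipophilicity, read by HPLC, measured as chromatographic lipophilicity, at pH 7.4 (on this read-out higher numbers stand for higher lipophilicity and lower numbers for lower lipophilicity), compound 1 gives 2.16, the highest of the three numbers. Compound 3, which gives 2.06, lies within the scatter of compound 1, so no order between these two can be claimed. Compound 2, the bare core without its two sugars, gives 1.29, which stands well beyond the scatter below compound 1.

Compound 4 `CCC(=O)NCCCO[C@H]1[C@H](C)O[C@@H](O[C@H]2[C@H](C)[C@@H](O[C@@H]3O[C@H](C)C[C@H](N(C)C)[C@H]3O)[C@](C)(O)C[C@@H](C)CN(C)[C@H](C)[C@@H](O)[C@](C)(O)[C@@H](CC)OC(=O)[C@@H]2C)C[C@@]1(C)OC` has not yet been measured. It keeps the whole frame of compound 1 and differs only at the far end of the side chain on the sugar, where the change is methyl in place of methoxy on a saturated chain carbon bound to a carbonyl carbon.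

Among the measured compounds shown here, no measured pair shows this exact change, so the size of the step must be estimated. Swapping a methoxy for a methyl on a chain carbon bound to a carbonyl carbon is a small change, and compound 4 is expected to read somewhat higher than compound 1 in this assay, a step of a number 0.39 log units higher from compound 1 to compound 4 (beyond the scatter), possibly only at the edge of the scatter. The estimate for compound 4 is therefore 2.55, with a range from 2.25 to 2.9.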

Compound 4, distribution coefficient: 2.54
Compound 4: middle estimate off by 0.01 log units, on the high side; the range from low to high includes it.
By their numbers in this assay, from the lowest: compound 2; then compounds 3 and 1 (each within the scatter of the next); then compound 4.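

Among the compounds shown here, until now no two measured compounds differed in only one place, so nothing showed whether this end of the side chain on the sugar matters for the read-out. In this assay, for the compounds shown here, the exchange of methoxy for methyl on a saturated chain carbon bound to a carbonyl carbon gives a number 0.38 log units higher from compound 1 to compound 4 (beyond the scatter), and this is the first single change whose size can be read directly. It shows that the far end of the chain is not a silent spot: losing one oxygen atom and one hydrogen-bond acceptor, while the rest of the frame stays the same, is enough to move the number by more than the usual scatter of repeated measurements.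

This remains one step at one place, so the compounds shown leave open whether an ethyl, a longer chain, an amine or a carboxylic acid on that same carbon would move the number further, not at all or the other way. Nothing shown here explains why the number moves, as no measurement bears on the cause of this step.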